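A few compounds are considered here, and "the series" means these few. Any claim that something is new, unique, unknown or untested is made for them only; others in the source may bear on it.

In a functional assay on DU-145 cells (Homo sapiens) for inhibition, read by trypan blue exclusion, with a stated time of 72 h (on this read-out higher numbers stand for weaker inhibition and lower numbers for stronger inhibition), compound 1 (`CCCn1c(=O)c(S(=O)(=O)c2ccc(F)cc2F)cc2cnc(Nc3ccc4[nH]ccc4c3)nc21`) gives 1000 nM and sits within the scatter of compound 2 (`Cn1c(=O)c(S(=O)(=O)c2ccc(F)cc2F)cc2cnc(Nc3cccc4[nH]ccc34)nc21`) at 750 nM and of compound 3 (`Cc1cc2cc(Nc3ncc4cc(S(=O)(=O)c5ccc(F)cc5F)c(=O)n(C)c4n3)ccc2[nH]1`) at 750 nM alike. Among the measured compounds shown here, compound 4 (`O=c1c(S(=O)(=O)c2ccc(F)cc2F)cc2cnc(Nc3ccc4[nH]ccc4c3)nc2n1CC1CCCC1`) differs from compound 1 by a single change (cyclopentyl in place of ethyl on a saturated chain carbon bound to an aromatic nitrogen) that no measured step covers. For the measured compounds named here, the only measured step (no change at the digits printed from compound 2 to compound 3 (within the scatter)) lies elsewhere, on a nitrogen on an aromatic ring, stays within the scatter and gives no direction for this change. No step beyond the scatter is therefore expected in this assay in either direction. The expected step (no change at the digits printed from compound 1 to compound 4 (within the scatter)) is an estimate only. For compound 4 the estimated value is 1000 nM with an expected range of 400 nM to 2500 nM as a working figure.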

Compound 4, half-maximal inhibitory concentration: 10000 nM
Estimate against measurement, compound 4: 10-fold (1.00 log units) below, and the stated range ends below it.
By their numbers in this assay, from the lowest: compounds 2, 3 and 1 (each within the scatter of the next); then compound 4.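

On a saturated chain carbon bound to an aromatic nitrogen, cyclopentyl in place of ethyl gives a 10-fold higher number from compound 1 to compound 4 (1.00 log units; beyond the scatter) in this assay, the first step in the series shown that lies beyond the scatter. This position therefore does not accept every carbon-only group alike, and the higher number stands for weaker inhibition. No supporting measurement bears on the reason for this step.

Going by these compounds, whether the step follows the ring itself or the carbon count remains open, and a straight pentyl chain at this place would bear on that. On these data alone, how an amine or a carboxylic acid on this chain would read also remains open.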